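The source may report more compounds than this note shows. Statements on the series, on what has been measured and on what is new or still open speak of the compounds shown alone.

Measured so far:
Compound 1 `Nc1ccc(-c2cnc(C(=O)CCCCCCc3ccccc3)o2)cc1` gives 90 nM in an assay (Rattus norvegicus) for inhibition of Fatty-acid amide hydrolase 1 (Homo sapiens); on this read-out higher numbers stand for weaker inhibition and lower numbers for stronger inhibition.
Compound 2 `Cc1cccnc1-c1cnc(C(=O)CCCCCCc2ccccc2)o1` gives 15 nM in this assay.

Within the data shown here, compound 2 has the lowest number of the two measured compounds, and the only measured step, a 6.0-fold lower number from compound 1 to compound 2 (0.78 log units; beyond the scatter), separates it from compound 1. Compound 3 `COc1ccnc(-c2cnc(C(=O)CCCCCCc3ccccc3)o2)c1` has not yet been measured. It differs from compound 2 by 4-methoxypyridin-2-yl in place of 3-methylpyridin-2-yl on an aromatic carbon. Among the measured compounds shown here, no measured step changes this same aromatic ring in this way; the step from compound 1 to compound 2 replaced a whole different group, so it bears only loosely on the question, and it shows that exchanging this ring can shift the number beyond the scatter. Without a direct precedent, the expected step in this assay is small, likely within the scatter, with slight weakening as the more probable direction. The estimate for compound 3 is 22 nM, with a range from 7 nM to 70 nM, which corresponds to an expected step of a 1.5-fold higher number from compound 2 to compound 3 (0.17 log units; within the scatter).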

Compound 3, inhibition constant: 0.8 nM
Estimate against measurement, compound 3: 28-fold (1.44 log units) above; measured number below the stated range.
By their numbers in this assay, from the lowest: compound 3; then compound 2; then compound 1.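

At this position on the shared core, exchanging one substituted pyridin-2-yl group for another can matter a great deal, which the earlier exchange of 4-aminophenyl for 3-methylpyridin-2-yl could not show. In this assay, 4-methoxypyridin-2-yl in place of 3-methylpyridin-2-yl gives a 19-fold lower number from compound 2 to compound 3 (1.27 log units; beyond the scatter) and in place of 4-aminophenyl gives a 110-fold lower number from compound 1 to compound 3 (2.05 log units; beyond the scatter) so the methoxy-bearing compound 3 is the strongest inhibitor of the three. Nothing available explains why the number falls so far.

This exchange alters both the substituent and its place on the ring, so the compounds shown leave open which of the two matters. Comparing compound 3 with its 3-methoxypyridin-2-yl and 4-methylpyridin-2-yl counterparts, and with plain pyridin-2-yl, would separate these contributions.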